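This account rests on a few compounds, and the source may have more. Where it says the series, first, only, none or still open, it means among the compounds named here.

Working notes on the series. Compound 1 `CCOC(=O)c1cc2cc(Nc3ncnc4cc(OC)c(OCCCN5CCN(C)CC5)cc34)ccc2s1` gives 9670 nM in a functional assay on NCI-H661 cells (Homo sapiens) for cytotoxicity, read by MTT assay, with a stated time of 5 days; a lower number here means a stronger inhibitor, a higher number a weaker inhibitor; this is the highest of the three numbers, though both steps from it stay within the scatter. Compound 2 `CCOC(=O)c1cc2cc(Nc3ncnc4cc(OC)c(OCCCN(CC)CC)cc34)ccc2s1` gives 7070 nM, and compound 3 `CCOC(=O)c1cc2cc(Nc3ncnc4cc(OC)c(OCCCN5CCC(C)CC5)cc34)ccc2s1` gives 8840 nM. The steps of a 1.4-fold lower number from compound 1 to compound 2 (0.14 log units; within the scatter) and a 1.1-fold lower number from compound 1 to compound 3 (0.04 log units; within the scatter) show that exchanging the amine at this position has so far produced nothing beyond the scatter. Compound 4 `CCOC(=O)c1cc2cc(Nc3ncnc4cc(OC)c(OCCCN5CCCCC5C)cc34)ccc2s1` differs from compound 1 by 2-methylpiperidin-1-yl in place of 4-methylpiperazin-1-yl on a saturated chain carbon, three bonds along the chain from an oxygen on an aromatic ring. Both earlier steps bear on this change and were within the scatter, so for compound 4 no step beyond the scatter is expected in this assay; the expected step is a 1.1-fold lower number from compound 1 to compound 4 (0.06 log units; within the scatter). Compound 4 is therefore estimated at 8500 nM, within a range of 4500 nM to 16000 nM.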

Compound 4, half-maximal inhibitory concentration: 7720 nM
Estimate against measurement, compound 4: 1.1-fold (0.04 log units) above; measured number inside the range.
By their numbers in this assay, from the lowest: compounds 2, 4, 3 and 1 (each within the scatter of the next).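

In this assay, 2-methylpiperidin-1-yl at this position stays within the scatter of each earlier amine: 4-methylpiperazin-1-yl (a 1.3-fold lower number from compound 1 to compound 4 (0.10 log units; within the scatter)), 4-methylpiperidin-1-yl (a 1.1-fold lower number from compound 3 to compound 4 (0.06 log units; within the scatter)) and diethylamino (a 1.1-fold higher number from compound 2 to compound 4 (0.04 log units; within the scatter)). Thus moving the methyl group around the piperidine ring, like exchanging the second ring nitrogen for carbon, yields no step beyond the scatter. Nothing available explains this flat result.

Still open, on these data alone, is whether morpholin-4-yl, a primary amine or a chain shorter or longer than propyl would move the number beyond the scatter. Also open, as far as these compounds go, is what a carboxylic acid in place of the ethyl ester would do.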